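A Halogenated Phenyl Replaces Thiophene in a Weak Series

A few compounds are considered here, and "the series" means these few. Any claim that something is new, unique, unknown or untested is made for them only; others in the source may bear on it.

For the measured compounds named here, compound 2 `Cn1c(=O)c(=O)n(C2CCCC2)c2nc(N/N=C/c3cccs3)ncc21` is the only member of this set with a numerical value: in a functional assay on PC-3 cells (Homo sapiens) for antiproliferative activity, read by MTT assay (a higher number here means a weaker inhibitor, a lower number a stronger inhibitor), compound 2 gives 75600 nM. Compound 1 `Cn1c(=O)c(=O)n(C2CCCC2)c2nc(N/N=C/c3ccc(O)cc3)ncc21` differs from it in one place. In this assay compound 1 reaches only a limit of the assay, > 100000 nM. Going by the values given here, the single measured step, an at least 1.3-fold lower number from compound 1 to compound 2 (0.12 log units; that floor lies within the scatter), is the only comparison available, and it rests on (the limit of > 100000 nM in this assay, at which 1 of the 2 values shown sits). Compound 3 `Cn1c(=O)c(=O)n(C2CCCC2)c2nc(N/N=C/c3ccc(F)cc3Br)ncc21` has not yet been measured. The change from compound 2 to compound 3 is 2-bromo-4-fluorophenyl in place of thiophen-2-yl on a carbon with a double bond to nitrogen. Among the compounds with values here, the only step that bears on it is the earlier exchange of one aromatic group for another on a carbon with a double bond to nitrogen, an at least 1.3-fold lower number from compound 1 to compound 2 (0.12 log units; that floor lies within the scatter), which was small; the set therefore gives no ground to expect a step beyond the scatter. For compound 3 the estimated step is a 1.3-fold lower number from compound 2 to compound 3 (0.10 log units; within the scatter). In this assay compound 3 is thus expected to give about 60000 nM, between 20000 nM and 180000 nM.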

Compound 3, half-maximal inhibitory concentration: 9250 nM
For compound 3 the middle estimate is 6.5-fold (0.81 log units) above the measured one; the whole stated range lies above it.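

In this assay, the group on the carbon with a double bond to nitrogen can shift the result beyond the scatter, which the exchange between compound 1 and compound 2 could not show. Putting 2-bromo-4-fluorophenyl in place of thiophen-2-yl gives an 8.2-fold lower number from compound 2 to compound 3 (0.91 log units; beyond the scatter). Putting the same group in place of 4-hydroxyphenyl gives an at least 10-fold lower number from compound 1 to compound 3 (1.03 log units; beyond the scatter), and this size is only a floor, as compound 1 stands at a limit of the assay: the limit of > 100000 nM in this assay, at which 1 of the 3 values shown sits.

The change from compound 2 to compound 3 replaces the ring and adds both halogens at once, so the compounds shown do not tell which of these parts carries the step. From the compounds shown here alone, whether a plain phenyl, a phenyl bearing bromine alone or fluorine alone, or a phenyl bearing a methoxy group would give a similar number remains open.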